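From 4-fluorobenzyl to 3,4-dimethoxybenzyl: what to expect

A few compounds are considered here, and "the series" means these few. Any claim that something is new, unique, unknown or untested is made for them only; others in the source may bear on it.

Three measured compounds share one core and differ only in the benzyl group on the amide-type nitrogen. In a functional assay on A2780 cells (Homo sapiens) for antiproliferative activity, read by resazurin assay, with a stated time of 72 h (a higher number here means a weaker inhibitor, a lower number a stronger inhibitor), compound 1 `Cc1cccc(Cc2n[nH]c3cc(O)c(C(=O)N(C)Cc4ccccc4)cc23)c1` gives 490 nM, compound 2 `Cc1cccc(Cc2n[nH]c3cc(O)c(C(=O)N(C)Cc4ccccc4Br)cc23)c1` gives 310 nM and compound 3 `Cc1cccc(Cc2n[nH]c3cc(O)c(C(=O)N(C)Cc4ccc(F)cc4)cc23)c1` gives 590 nM. Compound 3 does not stand apart from the other two, as its two steps show: a 1.2-fold higher number from compound 1 to compound 3 (0.08 log units; within the scatter) and a 1.9-fold higher number from compound 2 to compound 3 (0.28 log units; within the scatter).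

Going by the values given here, the next structure, compound 4 `COc1ccc(CN(C)C(=O)c2cc3c(Cc4cccc(C)c4)n[nH]c3cc2O)cc1OC`, keeps the core and changes only that group: 3,4-dimethoxyphenyl in place of 4-fluorophenyl on a saturated chain carbon bound to an amide-type nitrogen. Put simply, this is 3,4-dimethoxyphenyl in place of 4-fluorophenyl on a saturated chain carbon bound to an amide-type nitrogen.

The closest evidence comes from the other changes on this same ring. Placing bromo on compound 1 gave a 1.6-fold lower number from compound 1 to compound 2 (0.20 log units; within the scatter), and the fluoro change is the step to compound 3 already shown. Among the compounds with values here, neither step leaves the scatter, but no measured compound carries a 3,4-dimethoxyphenyl group, so this evidence is indirect and rests on only three compounds. No step beyond the scatter is therefore expected in this assay. The expected change is small: a 1.2-fold lower number from compound 3 to compound 4 (0.07 log units; within the scatter). The estimated value for compound 4 is 500 nM, with an expected range from 220 nM to 1100 nM.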

Compound 4, half-maximal inhibitory concentration: 3700 nM
Compound 4: the middle estimate sits 7.4-fold (0.87 log units) below what was measured; the measured number lies above the stated range.
By their numbers in this assay, from the lowest: compounds 2, 1 and 3 (each within the scatter of the next); then compound 4.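

Until now, the changes to the benzyl group on the amide-type nitrogen had all stayed within the scatter, so the position could have looked tolerant of any group placed there. In this assay, 3,4-dimethoxybenzyl ends that picture: it gives a 6.3-fold higher number from compound 3 to compound 4 (0.80 log units; beyond the scatter) and a 7.6-fold higher number from compound 1 to compound 4 (0.88 log units; beyond the scatter) and a 12-fold higher number from compound 2 to compound 4 (1.08 log units; beyond the scatter) as well, so compound 4 is weaker than each of the other three and this position does respond to what it carries. The entering group has 10 heavy atoms and 2 hydrogen-bond acceptors where 4-fluorophenyl has 7 and 0, but nothing measured here explains why the number rises.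

These compounds cannot show whether the two methoxy groups act together or whether one alone would raise the number as much, which a phenyl ring carrying a single methoxy group could test. As far as these compounds go, it also remains open how a hydroxy group, an amine or a longer chain at this place would compare with the 3,4-dimethoxybenzyl group.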